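A few compounds are considered here, and "the series" means these few. Any claim that something is new, unique, unknown or untested is made for them only; others in the source may bear on it.

Measured compounds in an assay on isolated protein for inhibition of 5-hydroxytryptamine receptor 4 (Homo sapiens); on this read-out higher numbers stand for weaker inhibition and lower numbers for stronger inhibition:
compound 1 `CC1(C)CCN(S(=O)(=O)CCCN2CCC(CNC(=O)c3cccc4c3OCCO4)CC2)CC1`: 0.126 nM
compound 2 `O=C(NCC1CCN(CCCS(=O)(=O)N2CCN(S(=O)(=O)c3ccc(F)cc3)CC2)CC1)c1cccc2c1OCCO2`: 0.0316 nM
compound 3 `CCCCN1CCC(CNC(=O)c2cccc3c2OCCO3)CC1`: 0.794 nM

Compound 1 stands second highest of the three numbers. Compound 2, which carries a different ring on the sulfonyl sulfur, gives a lower number than compound 1; compound 3, which has a methyl in place of the whole sulfonyl-piperidine group, gives a higher one, a 6.3-fold higher number from compound 1 to compound 3 (0.80 log units; beyond the scatter).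

Compound 4 `CCCC1CCN(S(=O)(=O)CCCN2CCC(CNC(=O)c3cccc4c3OCCO4)CC2)CC1` differs from compound 1 in one place: 4-propylpiperidin-1-yl in place of 4,4-dimethylpiperidin-1-yl on a sulfonyl sulfur. Going by the values given here, the only measured step that touches this region is a 6.3-fold higher number from compound 1 to compound 3 (0.80 log units; beyond the scatter), and there the entire sulfonyl-linked ring was removed; in compound 4 the ring and its sulfonyl remain, and only the substitution on the ring changes from two methyls to one propyl. Among the compounds with values here, no measured pair shows what such a change on this ring does, so the expectation rests on the ring being retained: a step of a 1.0-fold higher number from compound 1 to compound 4 (0.01 log units; within the scatter) is expected, within the scatter. Compound 4 is therefore estimated at 0.13 nM in this assay, with a range from 0.05 nM to 0.35 nM.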

Compound 4, inhibition constant: 0.0631 nM
Estimate against measurement, compound 4: 2.1-fold (0.31 log units) above, and the stated range covers the measured number.
By their numbers in this assay, from the lowest: compounds 2, 4 and 1 (each within the scatter of the next, the first and the last beyond it); then compound 3.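

In this assay, 4-propylpiperidin-1-yl in place of 4,4-dimethylpiperidin-1-yl on a sulfonyl sulfur gives a 2.0-fold lower number from compound 1 to compound 4 (0.30 log units; within the scatter) and so stays within the usual scatter, whereas removing the entire sulfonyl-linked group gives a 6.3-fold higher number from compound 1 to compound 3 (0.80 log units; beyond the scatter) and lies beyond it. At this position, the ring substitution can therefore change from two methyls to one propyl without a change that can be read in this assay. This holds for these two groups only, and no available evidence explains the result.

The compounds shown leave open whether an unsubstituted piperidine, or a piperidine carrying a hydroxyl, a carboxylic acid or a longer chain such as hexyl, would also stay within the scatter of compound 1. They also leave open whether a 4-propylpiperidin-1-yl group would behave the same way on a different core.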